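The source may report more compounds than this note shows. Statements on the series, on what has been measured and on what is new or still open speak of the compounds shown alone.

In a functional assay (aorta) for inhibition, with Oryctolagus cuniculus as the target (a lower number here means a stronger inhibitor, a higher number a weaker inhibitor), compound 1 `CC1=NC(=S)N(C(=O)OC2CCN(Cc3ccccc3)CC2)C(c2ccccc2C(F)(F)F)/C1=C(\O)OC(C)C` gives 5 nM. Compound 2 `CC1=C(C(=O)OC(C)C)C(c2ccccc2C(F)(F)F)N(C(=O)OC2CCN(Cc3ccccc3)CC2)C(=O)N1` gives 50 nM, the higher of the two numbers and so the weaker inhibitor of the pair, by a gap beyond the usual scatter. Compound 3 `CC1=C(C(=O)OC(C)C)C(c2cccc([N+](=O)[O-])c2)N(C(=O)OC2CCN(Cc3ccccc3)CC2)C(=O)N1` keeps the core of compound 2 and alters one group: 3-nitrophenyl in place of 2-(trifluoromethyl)phenyl on a saturated ring carbon. Put simply, 3-nitrophenyl stands in place of 2-(trifluoromethyl)phenyl on a saturated ring carbon. Among the compounds with values here, no measured pair shows this swap, so the data give no direct guide to its effect. Both groups hold one six-membered aromatic ring of carbon only, so the expectation in this assay is a small step, not beyond the scatter, leaning slightly towards a lower number. The estimated change is a 1.7-fold lower number from compound 2 to compound 3 (0.22 log units; within the scatter). For compound 3 the estimate is 30 nM, with an expected range from 8 nM to 110 nM.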

Compound 3, half-maximal inhibitory concentration: 12 nM
The estimate for compound 3 lay 2.5-fold (0.40 log units) above the measured number, within the range that was stated.
By their numbers in this assay, from the lowest: compound 1; then compound 3; then compound 2.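

At the saturated ring carbon next to the ring nitrogen, the choice of aryl group matters in this assay: 3-nitrophenyl in place of 2-(trifluoromethyl)phenyl gives a 4.2-fold lower number from compound 2 to compound 3 (0.62 log units; beyond the scatter), a step larger than the usual scatter. Both groups hold one six-membered aromatic ring of carbon only, so this position responds to what the phenyl ring carries, even with the ring itself unchanged. No measurement here explains why the number falls.

This single swap changes both the group on the phenyl ring and where that group stands, so the two changes cannot be separated. On these data alone, it also remains open where a plain phenyl, or a phenyl carrying a methoxy group or a nitrile, would fall relative to compound 2 and compound 3.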